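Swapping a cyclopentyl for an oxolane ring on the amine

A few compounds are considered here, and "the series" means these few. Any claim that something is new, unique, unknown or untested is made for them only; others in the source may bear on it.

Compound 1, with structure `Cn1c(-c2ccccc2)nc2c(NC3CCCC3)ncnc21`, is the starting point. In a functional assay on CHO cells for antagonist activity at adenosine receptor A2b (Homo sapiens), read by 33P incorporation, with a stated time of 20 min (on this read-out higher numbers stand for weaker inhibition and lower numbers for stronger inhibition), compound 1 gives 8510 nM. Two close relatives have been measured. Compound 2, `COc1ccc(-c2nc3c(NC4CCCC4)ncnc3n2C)cc1`, carries a methoxy group on its phenyl ring; in this assay compound 2 reaches only the limit > 30000 nM, which is a boundary of the assay rather than a number. Compound 3, `Cc1cccc(-c2nc3c(NC4CCCC4)ncnc3n2C)c1`, carries a methyl group instead; in this assay compound 3 gives 6030 nM. The measured steps are an at least 3.5-fold higher number from compound 1 to compound 2 (0.54 log units; beyond the scatter) and a 1.4-fold lower number from compound 1 to compound 3 (0.15 log units; within the scatter), so compound 1 and compound 3 cannot be told apart by the scatter, while compound 2 sits at the limit (the limit of > 30000 nM in this assay, at which 1 of the 3 values shown sits).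

Compound 4, `Cn1c(-c2ccccc2)nc2c(NC3CCOC3)ncnc21`, differs from compound 1 at another place altogether: oxolan-3-yl in place of cyclopentyl on a nitrogen on an aromatic ring. Both measured steps concern the phenyl ring, not the amine, so neither speaks directly to this change. With no direct guidance, a step of modest size at most is expected, with a lean toward a somewhat weaker inhibition because compound 1 starts from 8510 nM, already a high number in this assay. Compound 4 is therefore expected to give about 12000 nM, within 4000 nM to 30000 nM, an estimated step of a 1.4-fold higher number from compound 1 to compound 4 (0.15 log units; within the scatter).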

Compound 4, inhibition constant: 13300 nM
Estimate against measurement, compound 4: 1.1-fold (0.04 log units) below; low and high end bracket the measured number.
By their numbers in this assay, from the lowest: compounds 3, 1 and 4 (each within the scatter of the next, the first and the last beyond it). At a limit, above all of these: compound 2.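

For the compounds shown here, the earlier compounds changed only the phenyl ring, so this is the first reading at the amine, and in this assay the swap gives a 1.6-fold higher number from compound 1 to compound 4 (0.19 log units; within the scatter). Compound 1 and compound 4 therefore cannot be told apart: on this core, oxolan-3-yl, with its ring oxygen and one hydrogen-bond acceptor, can stand in for cyclopentyl with no change that exceeds the usual scatter, although this rests on a single pair of compounds. Nothing in the data shown explains this outcome.

As far as these compounds go, it remains open whether the same swap would read alike on a compound with a substituted phenyl ring, such as the 3-methylphenyl group of compound 3, since the oxolan-3-yl group appears here only with the unsubstituted phenyl ring. From the compounds shown here alone, it is also open how this nitrogen would tolerate other groups, such as a piperidin-4-yl ring with its basic amine, an open chain like 2-methoxyethyl, or a longer alkyl chain.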